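The source may hold more compounds than are shown below. What is called first, only, known or untested is meant among the compounds shown, and "the series" means these compounds.

In a functional assay (thoracic aorta) with Oryctolagus cuniculus as the target (on this read-out higher numbers stand for weaker inhibition and lower numbers for stronger inhibition), the measured compounds stand as follows:

compound 1 `CCO/C(O)=C1/C(C)=Nc2c(C#N)cnn2C1c1cccc(Cl)c1Cl`: 1.5 nM
compound 2 `CC1=Nc2c(C(N)=O)cnn2C(c2cccc([N+](=O)[O-])c2)/C1=C(/O)OC(C)C`: > 1000 nM, a limit of the assay and not a number
compound 3 `CC1=Nc2cc(=O)[nH]n2C(c2cccc([N+](=O)[O-])c2)/C1=C(/O)OC(C)C`: 318 nM

Compound 3 holds the higher of the two numbers in this assay; compound 1 holds the lower, and the gap between the two lies well beyond the usual scatter. Compound 2 sits at the limit of > 1000 nM in this assay, at which 1 of the 3 values shown sits, so it gives no number to compare.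

Compound 4 `CC1=Nc2cc(=O)n(Cc3ccccc3)n2C(c2cccc([N+](=O)[O-])c2)/C1=C(/O)OC(C)C` differs from compound 3 by benzyl in place of hydrogen on an aromatic nitrogen. Within the data shown here, no measured pair shows a change of this kind, so its direction cannot be read from the numbers at hand. The expected step is a 1.3-fold higher number from compound 3 to compound 4 (0.10 log units; within the scatter), which is taken as small, not clearly beyond the scatter in either direction. Compound 4 is therefore estimated at 400 nM in this assay, with a range from 100 nM to 2000 nM.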

Compound 4, half-maximal inhibitory concentration: 5 nM
Compound 4: middle estimate off by 80-fold (1.90 log units), on the high side; measured number below the stated range.
By their numbers in this assay, from the lowest: compound 1; then compound 4; then compound 3. At a limit, above all of these: compound 2.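

Benzyl in place of hydrogen on an aromatic nitrogen gives a 64-fold lower number from compound 3 to compound 4 (1.80 log units; beyond the scatter) in this assay. This is the first step shown at this nitrogen, and it shows that the position is far from indifferent: a substituent with one six-membered aromatic ring of carbon only, and with no hydrogen-bond donors or acceptors, goes with a much lower number. Nothing measured here accounts for the size of this step.

The compounds shown leave open whether the aromatic ring of the benzyl is what matters, or whether a methyl, a longer chain or a phenethyl on the same nitrogen would give a similar step. They also leave open how a benzyl bearing an amine or a carboxylic acid on its ring would read in this assay.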